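Swapping the aromatic group on the acetal carbon

The source may hold more compounds than are shown below. What is called first, only, known or untested is meant among the compounds shown, and "the series" means these compounds.

Compound 1, `O=C(O)CC/C=C\CC1COC(c2ccc3ccccc3c2)OC1c1cccnc1`: 50 nM
Compound 2, `CSc1ccccc1OC(C)(C)C1OCC(C/C=C\CCC(=O)O)C(c2cccnc2)O1`: 36 nM

In an assay for inhibition of Thromboxane-A synthase (Homo sapiens), using microsomes (on this read-out lower numbers stand for stronger inhibition and higher numbers for weaker inhibition), compound 1 has the higher of the two numbers, and compound 2 lies within the usual scatter of it. Compound 3, `CC(C)(Sc1ccccc1)C1OCC(C/C=C\CCC(=O)O)C(c2cccnc2)O1`, has not yet been measured. It differs from compound 1 in one place: a group of 10 heavy atoms (9 carbon, 1 sulfur; one six-membered aromatic ring of carbon only) in place of a group of 10 heavy atoms (10 carbon; 2 six-membered aromatic rings of carbon only), on a saturated ring carbon. Naphthalen-2-yl leaves, and a group with no common name, carrying one six-membered aromatic ring of carbon only and one hydrogen-bond acceptor, enters on a saturated ring carbon. Going by the values given here, with no measured step of this kind available, the step of a 1.3-fold lower number from compound 1 to compound 3 (0.10 log units; within the scatter) is expected to stay within the scatter. Compound 3 is estimated at 40 nM, between 15 nM and 120 nM.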

Compound 3, half-maximal inhibitory concentration: 40 nM
Beside the measured number, compound 3's estimate shows no gap at the digits printed, and the stated range covers the measured number.
By their numbers in this assay, from the lowest: compounds 2, 3 and 1 (each within the scatter of the next).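

In this assay, the saturated ring carbon between two ring oxygen atoms can carry either naphthalen-2-yl or the sulfur-containing group of compound 3, which has one six-membered aromatic ring instead of two (a 1.3-fold lower number from compound 1 to compound 3 (0.10 log units; within the scatter)). On the saturated chain carbon, phenylsulfanyl can also stand in place of 2-(methylsulfanyl)phenoxy (a 1.1-fold higher number from compound 2 to compound 3 (0.05 log units; within the scatter)). Nothing measured here explains this tolerance. Still open, as far as these compounds go, is whether this position would also accept a group carrying an amine, or a group as small as methyl.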